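From compound 3 to compound 4: one chloro step

The source may hold more compounds than are shown below. What is called first, only, known or untested is meant among the compounds shown, and "the series" means these compounds.

Measured in a functional assay on Jurkat cells (Homo sapiens) for cytotoxicity, read by MTT assay, with a stated time of 72 h (on this read-out higher numbers stand for weaker inhibition and lower numbers for stronger inhibition), so far:
compound 1 `O=C(Nc1ccccc1)Nc1ccc(C(=O)NO)cc1` gives 2500 nM
compound 2 `O=C(Nc1ccc(Cl)cc1)Nc1ccc(C(=O)NO)cc1` gives 1060 nM
compound 3 `O=C(CCc1ccc(NC(=O)Nc2ccccc2)cc1)NO` gives 1590 nM

Compound 3 stands at 1590 nM and is not clearly separated from the other two. Compound 2 at 1060 nM lies within the scatter of it, and the other measured step is a 1.6-fold lower number from compound 1 to compound 3 (0.20 log units; within the scatter) here. Compound 4 `O=C(CCc1ccc(NC(=O)Nc2ccc(Cl)cc2)cc1)NO` carries one change from compound 3, counted as chloro in place of hydrogen on an aromatic carbon in all: chloro in place of hydrogen on an aromatic carbon, para to a large group. The same change has been measured once, as a 2.4-fold lower number from compound 1 to compound 2 (0.37 log units; beyond the scatter) on the core of compound 1. A similar modest step toward a lower number is therefore expected in this assay from this single precedent. The estimated step is a 2.3-fold lower number from compound 3 to compound 4 (0.36 log units; beyond the scatter) for this change. The estimated value for compound 4 is 700 nM with an expected range from 300 nM to 1600 nM in this measurement.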

Compound 4, half-maximal inhibitory concentration: 410 nM
The estimate for compound 4 lay 1.7-fold (0.23 log units) above the measured number; measured number inside the range.
By their numbers in this assay, from the lowest: compound 4; then compounds 2, 3 and 1 (each within the scatter of the next, the first and the last beyond it).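

The chloro change now has a second reading on another core, with a 3.9-fold lower number from compound 3 to compound 4 (0.59 log units; beyond the scatter), and it points the same way as the first: the same change on two cores in this assay, a 2.4-fold lower number (0.37 log units; beyond the scatter) from compound 1 to compound 2 and a 3.9-fold lower number (0.59 log units; beyond the scatter) from compound 3 to compound 4, 1.6-fold (0.22 log units) apart, within the scatter of two such steps. The 2-(hydroxycarbamoyl)ethyl change now gives a 2.6-fold lower number from compound 2 to compound 4 (0.41 log units; beyond the scatter) with the chloro group present, a step beyond the scatter, yet it does not differ clearly from the same change without chloro: the same change on two cores in this assay, a 1.6-fold lower number (0.20 log units; within the scatter) from compound 1 to compound 3 and a 2.6-fold lower number (0.41 log units; beyond the scatter) from compound 2 to compound 4, 1.6-fold (0.22 log units) apart, within the scatter of two such steps.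

The compounds shown leave open whether fluoro, methoxy or an amine at this place would move the number the same way. They also leave open what a longer chain carrying the hydroxycarbamoyl group would give.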